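A few compounds are considered here, and "the series" means these few. Any claim that something is new, unique, unknown or untested is made for them only; others in the source may bear on it.

Of the compounds shown here, two carry numbers so far. Compound 1 `CC(Oc1ccccc1-c1cccnc1)C1=NCCN1` gives 933 nM in an assay on CHO cells for displacement of a labelled ligand from Alpha-2B adrenergic receptor (Homo sapiens); a lower number here means a stronger inhibitor, a higher number a weaker inhibitor. Compound 2 `CC(Oc1ccccc1-c1ccccc1[N+](=O)[O-])C1=NCCN1` gives 1550 nM in this assay, the higher of the two numbers, but its separation from compound 1 is within the scatter, so the two cannot be ordered. Compound 3 `Cc1ccccc1-c1ccccc1OC(C)C1=NCCN1` has not yet been measured. It differs from compound 2 in one place: methyl in place of nitro on an aromatic carbon. Among the compounds with values here, no step between measured compounds informs this change, so the expectation rests on the two values alone, which sit close together. Little movement beyond the scatter is expected from compound 2 to compound 3 in this assay; the step is estimated at a 1.4-fold lower number from compound 2 to compound 3 (0.15 log units; within the scatter). For compound 3 the expected value in this assay is therefore 1100 nM, with a range from 400 nM to 3000 nM.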

Compound 3, inhibition constant: 832 nM
Estimate against measurement, compound 3: 1.3-fold (0.12 log units) above; low and high end bracket the measured number.
By their numbers in this assay, from the lowest: compounds 3, 1 and 2 (each within the scatter of the next).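

In this assay, methyl in place of nitro on an aromatic carbon, ortho to a large group, gives a 1.9-fold lower number from compound 2 to compound 3 (0.27 log units; within the scatter), so the exchange stays within the scatter even though the 2 hydrogen-bond acceptors of nitro leave and none enters. The replacement of pyridin-3-yl by 2-methylphenyl gives a 1.1-fold lower number from compound 1 to compound 3 (0.05 log units; within the scatter), also within the scatter, so the ring nitrogen of compound 1 and the nitro group of compound 2 are each exchanged without a separable shift in this assay. Nothing available explains why these exchanges leave the numbers inseparable.

Still open, on these data alone, is whether any group at this place moves the number beyond the scatter, as an amine, a carboxylic acid or a methoxy group might. Also open, as far as these compounds go, is what plain hydrogen at this carbon would give against methyl and nitro.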